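Nitro for trifluoromethyl on the anilino ring of compound 3

This account rests on a few compounds, and the source may have more. Where it says the series, first, only, none or still open, it means among the compounds named here.

Measured compounds:
compound 1 `CC(C)c1ccc(-c2nc(SCc3cn(CC(=O)NC(=O)Nc4ccccn4)nn3)nc(Nc3ccc(F)cc3)c2C#N)cc1`; in a functional assay on ECa-109 cells (Homo sapiens) for inhibition, read by MTT assay, with a stated time of 72 h (a higher number here means a weaker inhibitor, a lower number a stronger inhibitor), compound 1 gives > 64000 nM, a limit of the assay and not a number.
compound 2 `CC(C)c1ccc(-c2nc(SCc3cn(CC(=O)NC(=O)Nc4ccccn4)nn3)nc(Nc3cccc(Cl)c3)c2C#N)cc1`; in this assay compound 2 gives 13300 nM.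
compound 3 `CC(C)c1ccc(-c2nc(SCc3cn(CC(=O)NC(=O)Nc4ccccn4)nn3)nc(Nc3cccc(C(F)(F)F)c3)c2C#N)cc1`; in this assay compound 3 gives 24200 nM.

Compound 3 holds the highest of the two numbers; compound 2 is nearest, and a 1.8-fold higher number from compound 2 to compound 3 (0.26 log units; within the scatter) stays within the scatter. Compound 1 sits at the limit of > 64000 nM in this assay, at which 1 of the 3 values shown sits. Compound 4 `CC(C)c1ccc(-c2nc(SCc3cn(CC(=O)NC(=O)Nc4ccccn4)nn3)nc(Nc3cccc([N+](=O)[O-])c3)c2C#N)cc1` differs from compound 3 by nitro in place of trifluoromethyl on an aromatic carbon. Among the measured compounds shown here, the only measured step at that aromatic carbon is a 1.8-fold higher number from compound 2 to compound 3 (0.26 log units; within the scatter), within the scatter; an at least 4.8-fold lower number from compound 1 to compound 2 (0.68 log units; beyond the scatter) and an at least 2.6-fold lower number from compound 1 to compound 3 (0.42 log units; beyond the scatter) change the ring as a whole and bear only loosely on this swap. No step beyond the scatter is therefore expected, a 1.2-fold lower number from compound 3 to compound 4 (0.08 log units; within the scatter). Compound 4 is estimated at 20000 nM, with a range from 7000 nM to 60000 nM.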

Compound 4, half-maximal inhibitory concentration: 31300 nM
Beside the measured number, compound 4's estimate is 1.6-fold (0.19 log units) below it; low and high end bracket the measured number.
By their numbers in this assay, from the lowest: compounds 2, 3 and 4 (each within the scatter of the next, the first and the last beyond it). At a limit, above all of these: compound 1.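

Nitro and trifluoromethyl on this aromatic carbon are not separated in this assay, with a 1.3-fold higher number from compound 3 to compound 4 (0.11 log units; within the scatter). Chloro and nitro are separated, with a 2.4-fold higher number from compound 2 to compound 4 (0.37 log units; beyond the scatter), although compound 3 lies within the scatter of both compound 2 and compound 4. The whole-ring change, an at least 2.0-fold lower number from compound 1 to compound 4 (0.31 log units; beyond the scatter), rests on compound 1, whose value is a limit and not a number: the limit of > 64000 nM in this assay, at which 1 of the 4 values shown sits.

From the compounds shown here alone, whether an amine or a carboxylic acid on this carbon would separate from chloro remains open. So does whether a methoxy group would.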